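Compound 1 to Compound 4: an Expected Step

The compounds below may be only part of what the source reports. "The series", "measured", "known", "first", "only" and "open" are said of these compounds alone.

Of the compounds shown here, three that share one core have been tested in a functional assay on A549 cells (Homo sapiens) for cytotoxicity, read by XTT assay, with a stated time of 24 h; a higher number here means a weaker inhibitor, a lower number a stronger inhibitor. Compound 1 `Fc1cc(F)cc(/C=N/NC(=S)Nc2cccc3ccccc23)c1` gives 500 ug/mL in this assay, the highest of the three numbers and so the weakest inhibitor among them. Compound 2 `Fc1ccc(/C=N/NC(=S)Nc2cccc3ccccc23)cc1F` gives 125 ug/mL, and compound 3 `Fc1ccc(Oc2ccc(/C=N/NC(=S)Nc3cccc4ccccc34)cc2)cc1` gives 62.5 ug/mL. Among the measured compounds shown here, the one measured step that alters a single place, a 4.0-fold lower number from compound 1 to compound 2 (0.60 log units; beyond the scatter), shows that moving fluorines around on the same ring can shift the number by a clear margin.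

Compound 4 `Fc1cccc(Cl)c1/C=N/NC(=S)Nc1cccc2ccccc12` differs from compound 1 at that same place: 2-chloro-6-fluorophenyl in place of 3,5-difluorophenyl on a carbon with a double bond to nitrogen. For the measured compounds named here, no measured pair exchanges a fluorine for a chlorine, so the only guide is the step between compound 1 and compound 2, which was of modest size. A change of similar kind on the same ring is therefore expected to give a step of similar size toward a lower number, a 2.0-fold lower number from compound 1 to compound 4 (0.30 log units; within the scatter), although a result within the scatter of compound 1 cannot be ruled out. Compound 4 is accordingly expected to give 250 ug/mL in this assay, with a plausible range from 62.5 ug/mL to 500 ug/mL.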

Compound 4, half-maximal inhibitory concentration: 125 ug/mL
Beside the measured number, compound 4's estimate is 2.0-fold (0.30 log units) above it; measured number inside the range.
By their numbers in this assay, from the lowest: compounds 3, 2 and 4 (each within the scatter of the next); then compound 1.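

In this assay, the place on the carbon with a double bond to nitrogen now has a second ring that lowers the number relative to the 3,5-difluorophenyl ring, with a 4.0-fold lower number from compound 1 to compound 4 (0.60 log units; beyond the scatter) as the step. This new ring brings in a chlorine, yet the step to it from the 3,4-difluorophenyl ring shows no change at the digits printed from compound 2 to compound 4 (within the scatter) as its outcome, so 2-chloro-6-fluorophenyl and 3,4-difluorophenyl cannot be told apart here, and compound 1 alone keeps the higher number among these three compounds. Nothing available explains why these rings differ in this way.

The compounds shown leave open whether this place tolerates a ring carrying something other than halogen, such as an amine, a methoxy group or a carboxylic acid. They also leave open whether a ring with chlorine alone, for example 2,6-dichlorophenyl, would match compound 4 or compound 1, and so whether the fluorine in compound 4 matters at all for this number.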